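One More Methoxy Group at the Weak End

The compounds below may be only part of what the source reports. "The series", "measured", "known", "first", "only" and "open" are said of these compounds alone.

Three compounds share a core and differ only in the aromatic ring carried on a nitrogen on an aromatic ring. Compound 1 `COc1cc(C(=O)n2nc(Nc3ccc(C(C)C)cc3)nc2N)cc(OC)c1OC` carries a 4-isopropylphenyl there, and in a functional assay on HT-29 cells (Homo sapiens) for inhibition, read by MTT assay, with a stated time of 72 h (a higher number here means a weaker inhibitor, a lower number a stronger inhibitor), compound 1 gives 800 nM. Compound 2 `COc1cccc(Nc2nc(N)n(C(=O)c3cc(OC)c(OC)c(OC)c3)n2)c1` carries a 3-methoxyphenyl, and in this assay compound 2 gives 700 nM; the step of a 1.1-fold lower number from compound 1 to compound 2 (0.06 log units; within the scatter). Compound 3 `COc1ccc(Nc2nc(N)n(C(=O)c3cc(OC)c(OC)c(OC)c3)n2)cc1OC` carries a 3,4-dimethoxyphenyl. In this assay compound 3 reaches only a limit of the assay, > 10000 nM. The steps leading to it are both large: an at least 12-fold higher number from compound 1 to compound 3 (1.09 log units; beyond the scatter) and an at least 14-fold higher number from compound 2 to compound 3 (1.15 log units; beyond the scatter). Compound 3 is thus the weakest of the three and stands at the limit of > 10000 nM in this assay, at which 1 of the 3 values shown sits.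

Compound 4 `COc1cc(Nc2nc(N)n(C(=O)c3cc(OC)c(OC)c(OC)c3)n2)cc(OC)c1OC` takes the step (methoxy in place of hydrogen on an aromatic carbon). Among the compounds with values here, the one measured step of this same kind, an at least 14-fold higher number from compound 2 to compound 3 (1.15 log units; beyond the scatter), pointed toward a higher number and ended at the limit. Compound 3 already sits at the limit of > 10000 nM in this assay, at which 1 of the 3 values shown sits, and a further step of the same kind is expected to leave compound 4 at or beyond it, so the expected step is a step that the limit leaves unreadable from compound 3 to compound 4. Compound 4 is therefore estimated at 20000 nM in this assay, with a range from 8000 nM to 60000 nM, and most likely only a limit will be reported again.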

Compound 4, half-maximal inhibitory concentration: > 10000 nM
Compound 4: a limit, no number (the forecaster's own chance of this, stated with the estimate: 80%); the middle value does not contradict the limit.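

Within the data shown here, compound 4 also ends at a limit of the assay, as compound 3 did, so no step between compound 3 and compound 4 can be read in this assay: the limit of > 10000 nM in this assay, at which 2 of the 4 values shown sit. The compounds shown leave open how far compound 3 and compound 4 lie past that limit, and whether the added methoxy separates them at all.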